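The compounds below may be only part of what the source reports. "The series", "measured", "known", "first", "only" and "open" are said of these compounds alone.

Compound 2: `CNc1nc(NC2(C#N)CCCCC2)nc(-n2ccnc2)n1`, 1050 nM
Compound 1: `CNc1nc(NC2(C#N)CCCCC2)nc(-n2cccn2)n1`, > 5000 nM

Within the data shown here, in an in vitro assay on Sf21 cells for inhibition of high affinity 3',5'-cyclic-AMP phosphodiesterase 7A (Homo sapiens) (a higher number here means a weaker inhibitor, a lower number a stronger inhibitor), compound 2 gives 1050 nM, the only number in hand. Compound 1 reports only a limit, > 5000 nM, and so sits at the limit of > 5000 nM in this assay, at which 1 of the 2 values shown sits. Among the measured compounds shown here, the single measured step, an at least 4.7-fold lower number from compound 1 to compound 2 (0.67 log units; beyond the scatter), is the one that bears on the present change, and it runs in the opposite sense. Compound 3 is `CNc1nc(NC2(C#N)CCCCC2)nc(N(C)C)n1`; it takes (dimethylamino in place of 1H-imidazol-1-yl on an aromatic carbon). That step showed the five-membered aromatic ring at this carbon carrying the gain, so removing it for dimethylamino is expected to weaken inhibition, possibly back to the limit. Compound 3 is estimated at 5000 nM, range 1500 nM to 20000 nM, a step of a 4.8-fold higher number from compound 2 to compound 3 (0.68 log units; beyond the scatter).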

Compound 3, half-maximal inhibitory concentration: > 5000 nM
Compound 3: no number, only a limit; the forecaster's own chance of this, stated with the estimate: 50%; the middle value lies on the limit itself.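

In this assay the loss seen with 1H-pyrazol-1-yl is not specific to that ring, as dimethylamino at the same carbon gives an at least 4.7-fold higher number from compound 2 to compound 3 (0.67 log units; beyond the scatter) against 1H-imidazol-1-yl. Compound 3 gives > 5000 nM as a limit, not a number. Of the three groups at this carbon, only 1H-imidazol-1-yl gives a number, and the other two share one limit: the limit of > 5000 nM in this assay, at which 2 of the 3 values shown sit.

The step between compound 1 and compound 3 cannot be read, so those two groups stay unranked. Going by these compounds, whether a 1,2,4-triazol-1-yl ring or a morpholine ring at this carbon would give a number remains open.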